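Swapping tert-butoxycarbonyl for methyl on a ring nitrogen

The source may hold more compounds than are shown below. What is called first, only, known or untested is meant among the compounds shown, and "the series" means these compounds.

Compound 3 `CN(Cc1nc2cccc(N3CCN(C(=O)OC(C)(C)C)CC3)c2[nH]1)C1CCCc2cccnc21` has been tested in an ADME assay on HOS cells (Homo sapiens) for cytotoxicity; on this read-out lower numbers stand for higher toxicity in this test and higher numbers for lower toxicity in this test. Compound 3 gives > 10000 nM, which is a limit of the test and not a number, so its position is known from one side only. Compound 1 `CN(Cc1nc2cccc(C(=O)NCCCCN)c2[nH]1)C1CCCc2cccnc21` gives > 20000 nM, and this is also a limit. Compound 2 `CN(C)CCCc1cccc2nc(CN(C)C3CCCc4cccnc43)[nH]c12` is the only one of the three with an actual number, at 7500 nM.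

Compound 4 `CN1CCN(c2cccc3nc(CN(C)C4CCCc5cccnc54)[nH]c23)CC1` differs from compound 3 in one place: methyl in place of tert-butoxycarbonyl on an amine nitrogen in a ring. Among the measured compounds shown here, no measured step covers this exact swap. For the measured compounds named here, the nearest evidence is the single measured step, an at least 2.6-fold lower number from compound 1 to compound 2 (0.42 log units; beyond the scatter), which brought in a 3-(dimethylamino)propyl group. Compound 2 thus has an amine nitrogen carrying methyl, as compound 4 will. On that resemblance to compound 2 at 7500 nM, a modest move to a lower number is expected in this assay, although a single step is thin support. The estimated step is an at least 1.1-fold lower number from compound 3 to compound 4 (0.04 log units; that floor lies within the scatter). Compound 4 is expected at 9000 nM, with an estimated range of 3500 nM to 25000 nM.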

Compound 4, half-maximal cytotoxic concentration: 14000 nM
Estimate against measurement, compound 4: 1.6-fold (0.19 log units) below; low and high end bracket the measured number.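

In this assay, compound 3 gives > 10000 nM, which is a limit and not a number, so the steps that start from it cannot be read: the limit of > 10000 nM in this assay, at which 1 of the 4 values shown sits.

Among the compounds shown here, what the methyl compound adds is a real number for a group on this ring nitrogen, and so a first firm reading of the six-membered ring with 2 nitrogen on the shared core. Set against the side chain of compound 2, the result is a 1.9-fold higher number from compound 2 to compound 4 (0.27 log units; within the scatter), so 4-methylpiperazin-1-yl and 3-(dimethylamino)propyl on that aromatic carbon cannot be told apart in this assay. Against the amide side chain of compound 1, whose value is also a limit, the result is an at least 1.4-fold lower number from compound 1 to compound 4 (0.15 log units; that floor lies within the scatter), so only a floor is known and it does not clear the usual scatter.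

For the compounds shown here, still open is whether tert-butoxycarbonyl shifts the read-out at all compared with methyl, since only one side of that comparison is a number. Also open, going by these compounds, is how a bare ring amine, an acetyl group or a longer alkyl chain on the same nitrogen would read in this assay.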